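A few compounds are considered here, and "the series" means these few. Any claim that something is new, unique, unknown or untested is made for them only; others in the source may bear on it.

In a functional assay for inhibition, with Homo sapiens as the target (on this read-out higher numbers stand for weaker inhibition and lower numbers for stronger inhibition), two compounds have been measured so far: compound 1 `O=C(O)c1cc(-c2ccccc2)c2ccc(OCc3cccc(C4(O)CCOCC4)c3)cc2c1` gives 190 nM, and compound 2 `OC1(c2cccc(COc3ccc4c(-c5ccoc5)cc(C5=NCCO5)cc4c3)c2)CCOCC1` gives 3 nM. Compound 2 thus holds the lower of the two numbers, meaning the stronger inhibition, and the gap lies beyond the usual scatter of repeat measurements. Compound 3 `OC1(c2cccc(COc3ccc4c(-c5ccoc5)cc(-c5nc6ccccc6s5)cc4c3)c2)CCOCC1` differs from compound 2 in one place: a group of 9 heavy atoms (7 carbon, 1 nitrogen, 1 sulfur; one five-membered aromatic ring with 2 hetero atoms, one six-membered aromatic ring of carbon only) in place of a group of 5 heavy atoms (3 carbon, 1 nitrogen, 1 oxygen; one five-membered non-aromatic ring with 2 hetero atoms), on an aromatic carbon. A 1,3-benzothiazol-2-yl group replaces a group built on a five-membered non-aromatic ring, on an aromatic carbon meta to a furan-3-yl group. Going by the values given here, no measured pair shows this exchange on its own, so any expectation here is loose. With compound 2 at 3 nM, the number has more room to rise than to fall. A moderate loss of inhibition, beyond the scatter, is expected, with an estimated change of an 8.3-fold higher number from compound 2 to compound 3 (0.92 log units; beyond the scatter). Compound 3 is estimated at 25 nM, with an expected range of 5 nM to 150 nM.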

Compound 3, half-maximal inhibitory concentration: > 62 nM
Compound 3: only a limit was reported; the forecaster's own chance of this, stated with the estimate: 5%; middle value at least 2.4-fold (0.39 log units) away from the limit.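

Compounds 2 and 3 are the first pair shown that differs only at this aromatic carbon, meta to a furan-3-yl group, and so the first view of this position on its own. In this assay, putting 1,3-benzothiazol-2-yl in place of the five-membered non-aromatic ring gives an at least 20-fold higher number from compound 2 to compound 3 (1.31 log units; beyond the scatter), so inhibition here does not survive every ring system at this position. Compound 3 carries only a limit, so the full size of this loss stays unknown: the limit of > 62 nM in this assay, at which 1 of the 3 values shown sits.

The pair cannot separate the effect of the five-membered aromatic ring from that of the fused six-membered carbon ring, since both enter together. A thiazol-2-yl group, which has the five-membered aromatic ring alone, would pull these two parts apart, and a benzoxazol-2-yl group would test the sulfur atom.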